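Swapping the Group on a Sulfonamide Nitrogen

A few compounds are considered here, and "the series" means these few. Any claim that something is new, unique, unknown or untested is made for them only; others in the source may bear on it.

Three small compounds have so far been measured in a functional assay on HeLa cells (Homo sapiens) for cytotoxicity, read by resazurin assay, with a stated time of 72 h; on this read-out lower numbers stand for stronger inhibition and higher numbers for weaker inhibition. Compound 1 `CCOC(=S)SCC(=O)c1ccc(OC)cc1` gives 4640 nM. Compound 2 `CCSC(=S)SCC(=O)c1cccc(CNC(C)=O)c1` gives 11300 nM. Compound 3 `CCSC(=S)SCC(=O)c1cccc(S(=O)(=O)Nc2ccc(OC)cc2)c1` gives 5170 nM, which is level with compound 1 within the usual scatter of repeated measurements. Compound 2 stands apart from both, with a higher number beyond that scatter, so compound 3 belongs to the stronger pair of this small set.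

Compound 4 `CCSC(=S)SCC(=O)c1cccc(S(=O)(=O)Nc2cccc(C(N)=O)c2)c1` has not yet been measured. It keeps all of compound 3 except one group, with 3-carbamoylphenyl in place of 4-methoxyphenyl on a sulfonamide nitrogen.

For the measured compounds named here, no two measured compounds differ in just one place, so the data offer no direct guide to the size of this step. Going by the values given here, compound 2, at 11300 nM, is the only measured compound with a carbonyl amide, as compound 4 has. It differs from compound 3 by far more than this swap, however, so it gives only a weak hint towards weaker inhibition. A small drift in that direction is expected, probably not beyond the scatter, and the estimated change is a 1.4-fold higher number from compound 3 to compound 4 (0.13 log units; within the scatter). For compound 4, the estimated value in this assay is 7000 nM, with an expected range from 2800 nM to 18000 nM.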

Compound 4, half-maximal inhibitory concentration: 7740 nM
Beside the measured number, compound 4's estimate is 1.1-fold (0.04 log units) below it; low and high end bracket the measured number.
By their numbers in this assay, from the lowest: compounds 1, 3, 4 and 2 (each within the scatter of the next, the first and the last beyond it).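

For the compounds shown here, this is the first pair in the set that differs in just one place, so it gives the first direct reading of the group on the sulfonamide nitrogen: in this assay, the swap gives a 1.5-fold higher number from compound 3 to compound 4 (0.18 log units; within the scatter), which means the two compounds cannot be told apart. At this position, then, exchanging 4-methoxyphenyl for 3-carbamoylphenyl leaves the read-out level within the usual scatter, even though the entering group carries a hydrogen-bond donor that the leaving group lacks, while both keep a six-membered aromatic ring. Nothing measured here accounts for this outcome.

The swap changes both the group carried on the ring and its numbered place, as the two names show, so this single step cannot separate those two changes or show how far the position's apparent flexibility extends. Going by these compounds, a plain phenyl ring, a carboxylic acid in place of the carbamoyl group, or an ethyl chain in place of the ring on the sulfonamide nitrogen would test that flexibility further, and the answer remains open.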